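Swapping Methoxymethyl for Ethoxycarbonyl on a Saturated Ring Carbon

The compounds below may be only part of what the source reports. "The series", "measured", "known", "first", "only" and "open" are said of these compounds alone.

Compound 1, `COCC1CN(S(=O)(=O)c2ccc(F)cc2)CCN1C(C)=O`: in an ADME assay on a cell-free system (plasma, Rattus norvegicus, strain Sprague-Dawley) for metabolic stability, read by LC-MS, tested at 1 uM (a lower number here means that the compound disappears faster, a higher number that the compound lasts longer), compound 1 gives >= 4 h, a limit of the assay and not a number.
Compound 2, `COCC1CN(C(C)=O)CCN1S(=O)(=O)c1ccc(F)cc1`: in this assay compound 2 gives >= 4 h, likewise a limit of the assay.
Compound 3, `CCOC(=O)C1CN(S(=O)(=O)c2ccc(F)cc2)CCN1C(C)=O`: in this assay compound 3 gives 0.617 h.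

Compound 1 and compound 2 are built from the same atoms joined differently; the difference between the two cores is not broken down here. Compound 3 arises from compound 1 by ethoxycarbonyl in place of methoxymethyl on a saturated ring carbon, and this gave an at least 6.4-fold lower number from compound 1 to compound 3 (0.81 log units; beyond the scatter). Compound 4, `CCOC(=O)C1CN(C(C)=O)CCN1S(=O)(=O)c1ccc(F)cc1`, is not yet measured and arises from compound 2 by ethoxycarbonyl in place of methoxymethyl on a saturated ring carbon. The surroundings of the place are not identical: in compound 1 the carbon is next to the ring atom that bears an acetyl group and two ring bonds from the ring atom that bears a large group, whereas in compound 2 it is next to the ring atom that bears a large group and two ring bonds from the ring atom that bears an acetyl group, so this is the same kind of change rather than the same change. In this assay compound 4 is expected to show an at least 5.7-fold lower number from compound 2 to compound 4 (0.75 log units; beyond the scatter), a step of similar size to an at least 6.4-fold lower number from compound 1 to compound 3 (0.81 log units; beyond the scatter). Going by these compounds, because compound 2 sits at the limit of >= 4 h in this assay, at which 2 of the 3 values shown sit, the true size of that step remains open. Compound 4 is estimated at 0.7 h, likely between 0.25 h and 2.5 h.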

Compound 4, half-life in the plasma assay: 0.35 h
Estimate against measurement, compound 4: 2.0-fold (0.30 log units) above, within the range that was stated.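

In the plasma assay the same change on the second core gives an at least 11-fold lower number from compound 2 to compound 4 (1.05 log units; beyond the scatter), so the number falls on both cores shown, though two cores are a small basis for any rule. How far the two steps differ in size cannot be said: the same change on two cores in the plasma assay, an at least 6.4-fold lower number (0.81 log units; beyond the scatter) from compound 1 to compound 3 and an at least 11-fold lower number (1.05 log units; beyond the scatter) from compound 2 to compound 4; the limit leaves it open whether they differ. In a physicochemical assay for metabolic stability, read by LC-MS, in phosphate buffer, tested at 1 uM (a lower number here means that the compound disappears faster, a higher number that the compound lasts longer), compound 2 gives >= 4 h, a limit of the assay. In the physicochemical assay compound 4 gives >= 4 h, likewise a limit of the assay. So no step can be read there and this change shows no readable effect: the limit of >= 4 h in the physicochemical assay, at which 2 of the 2 values shown sit.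

The compounds shown leave open how a carboxylic acid or a simple amide on the same saturated ring carbon would behave in the plasma assay. They also leave open whether a longer ether chain in place of methoxymethyl would keep the compound at the limit.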